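Ethyl ester series: dimethylamino replacing piperidin-1-yl

The compounds below may be only part of what the source reports. "The series", "measured", "known", "first", "only" and "open" are said of these compounds alone.

Measured so far:
compound 1 `CCOC(=O)c1cnc(NCC2CCCCC2)n2nc(-c3ccco3)nc12` — 41.2 nM
compound 2 `CCOC(=O)c1cnc(N2CCCCC2)n2nc(-c3ccco3)nc12` — 1770 nM

In an assay on CHO cells for displacement of a labelled ligand from adenosine receptor A3 (Homo sapiens) (a higher number here means a weaker inhibitor, a lower number a stronger inhibitor), compound 2 gives 1770 nM, the highest number of the two, with compound 1 at 41.2 nM. Among the measured compounds shown here, the one measured step, a 43-fold higher number from compound 1 to compound 2 (1.63 log units; beyond the scatter), replaced a group carrying a hydrogen-bond donor by one with none. Compound 3 `CCOC(=O)c1cnc(N(C)C)n2nc(-c3ccco3)nc12` differs from compound 2 by dimethylamino in place of piperidin-1-yl on an aromatic carbon; both groups carry 0 hydrogen-bond donors and 1 hydrogen-bond acceptor, so the measured step does not transfer directly. Compound 3 is therefore expected near compound 2, step a 1.4-fold higher number from compound 2 to compound 3 (0.15 log units; within the scatter), estimated at 2500 nM (range 600 nM to 10000 nM).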

Compound 3, inhibition constant: 275 nM
Compound 3: the middle estimate sits 9.1-fold (0.96 log units) above what was measured; measured number below the stated range.
By their numbers in this assay, from the lowest: compound 1; then compound 3; then compound 2.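

The position responds even when hydrogen-bond donor and acceptor counts stay the same: replacing the six-membered ring with the smaller, ring-free dimethylamino gives a 6.4-fold lower number from compound 2 to compound 3 (0.81 log units; beyond the scatter). Donor loss therefore does not fix the level in this pair, and a 6.7-fold higher number from compound 1 to compound 3 (0.82 log units; beyond the scatter) is a smaller loss than the one seen with piperidin-1-yl. No evidence explains either step. Open, as far as these compounds go, is whether methylamino, which keeps the amine hydrogen on a small group, would match compound 1, and whether pyrrolidin-1-yl falls between compound 2 and compound 3.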